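Propoxy in place of methylamino on the shared core

The source may hold more compounds than are shown below. What is called first, only, known or untested is meant among the compounds shown, and "the series" means these compounds.

Measured so far:
compound 1 `CNc1nc(N)c2nc(O)n(Cc3ccccc3)c2n1`, 1 uM
compound 2 `NNc1nc2c(N)ncnc2n1Cc1ccccc1`, > 10 uM

Among the measured compounds shown here, in a functional assay (spleen, spleen) for activation, with Mus musculus as the target (on this read-out higher numbers stand for an effect only at larger amounts of compound and lower numbers for an effect already at smaller amounts), compound 1 gives 1 uM, the only number in this set. For compound 2 the read-out is a limit of the assay, > 10 uM, and no number stands for it; (the limit of > 10 uM in this assay, at which 1 of the 2 values shown sits). For the measured compounds named here, compound 1 thus stands as the sole compound with a measured number, and the gap to compound 2 cannot be sized beyond what that limit shows.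

Compound 3 `CCCOc1nc(N)c2nc(O)n(Cc3ccccc3)c2n1` has not yet been tested. It differs from compound 1 in one place: propoxy in place of methylamino on an aromatic carbon. Going by the values given here, no step between two measured compounds is available to calibrate this change, so the expectation rests on compound 1 alone. The change is expected to move the number only modestly, within or close to the usual scatter, if anything toward smaller amounts; the estimated step is a 2.0-fold lower number from compound 1 to compound 3 (0.30 log units; within the scatter). In this assay compound 3 is expected to give about 0.5 uM, with a range from 0.1 uM to 3 uM.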

Compound 3, minimum effective concentration: 0.01 uM
For compound 3 the middle estimate is 50-fold (1.70 log units) above the measured one; measured number below the stated range.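

In this assay, the exchange on the aromatic carbon between two ring nitrogen atoms gives a 100-fold lower number from compound 1 to compound 3 (2.00 log units; beyond the scatter), so this position on the shared core responds strongly to the group it carries, and the step lies beyond the scatter. The exchange replaces methylamino (2 heavy atoms, 1 hydrogen-bond donor) with propoxy (4 heavy atoms, 0 hydrogen-bond donors), so the attached atom, the chain size and the donor count all change together in this one step, and propoxy is the better of the two groups compared here. Nothing measured in this set accounts for the size of the step.

Among the compounds shown here, the single pair cannot separate the contribution of the ring-bound oxygen from that of the chain length, and propylamino on the same carbon would hold the chain while restoring the nitrogen, whereas ethoxy or butoxy would hold the oxygen while varying the chain. On these data alone, whether the response keeps rising with a longer chain, or falls away beyond propoxy, remains open.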